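Moving the Hydroxyl Around a Hydrazone Phenyl Ring

This account rests on a few compounds, and the source may have more. Where it says the series, first, only, none or still open, it means among the compounds named here.

Three hydrazones sharing one core have been tested in an ADME assay on HEL cells (Homo sapiens) for cytotoxicity; on this read-out lower numbers stand for higher toxicity in this test and higher numbers for lower toxicity in this test. Compound 1 `O=C(COc1cccc2ccccc12)N/N=C/c1c(O)ccc2ccccc12` gives 1.94 ug/mL. Compound 2 `O=C(COc1cccc2ccccc12)N/N=C/c1ccc(O)cc1` gives 60.6 ug/mL, the highest of the three numbers, and compound 3 `COc1ccc(/C=N/NC(=O)COc2cccc3ccccc23)cc1OC` gives 52.6 ug/mL, which lies within the scatter of compound 2. Compound 1 sits far lower, well beyond the scatter. Compound 4 `O=C(COc1cccc2ccccc12)N/N=C/c1cccc(O)c1` has not yet been measured; it differs from compound 2 in one place: 3-hydroxyphenyl in place of 4-hydroxyphenyl on a carbon with a double bond to nitrogen. For the measured compounds named here, no measured pair shows what this change does. In this assay the step of a 1.2-fold lower number from compound 2 to compound 4 (0.08 log units; within the scatter) is expected to be small, with no direction that goes beyond the scatter. Compound 4 is therefore expected to give 50 ug/mL, with a range from 20 ug/mL to 120 ug/mL.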

Compound 4, half-maximal cytotoxic concentration: 62.7 ug/mL
For compound 4 the middle estimate is 1.3-fold (0.10 log units) below the measured one, and the stated range covers the measured number.
By their numbers in this assay, from the lowest: compound 1; then compounds 3, 2 and 4 (each within the scatter of the next).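

In this assay the step with 3-hydroxyphenyl in place of 4-hydroxyphenyl is a 1.0-fold higher number from compound 2 to compound 4 (0.01 log units; within the scatter) and so the two compounds cannot be told apart. For the compounds shown here, for this pair, where the hydroxyl sits on the phenyl ring makes no difference beyond the scatter, something the earlier compounds, with no matched pair among them, could not show. No measurement available here explains this result. Going by these compounds, whether an amine or a carboxylic acid in place of the hydroxyl would behave the same way stays open. So does what sets compound 1 apart, since it differs from the others in more than one place.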